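A few compounds are considered here, and "the series" means these few. Any claim that something is new, unique, unknown or untested is made for them only; others in the source may bear on it.

All three measured compounds were tested in a functional assay on H157 cells (Homo sapiens) for antiproliferative activity, read by trypan blue exclusion; a lower number here means a stronger inhibitor, a higher number a weaker inhibitor.
Compound 1 `COc1ccc(/C=C/S(=O)(=O)Cc2ccc(OC)cc2)cc1` gives > 20000 nM, a limit of the assay.
Compound 2 `COc1ccc(CS(=O)(=O)/C=C/c2ccc(OC)c(OC)c2)cc1` gives > 20000 nM, a limit of the assay.
Compound 3 `COc1ccc(CS(=O)(=O)/C=C/c2ccc(OC)cc2OC)cc1` gives > 20000 nM, a limit of the assay.

Compound 3 therefore stands where every value shown stands, at the limit (the limit of > 20000 nM in this assay, at which 3 of the 3 values shown sit), so no number places it against the others. The change to compound 4 `COc1ccc(CS(=O)(=O)/C=C/c2ccc(OC)c(OC)c2OC)cc1` is methoxy in place of hydrogen on an aromatic carbon. Two earlier steps made the same kind of change: a step that the two limits leave unreadable from compound 1 to compound 2 and a step that the two limits leave unreadable from compound 1 to compound 3. Neither gives a readable size, so no direction and no size can be taken from them. The expectation for compound 4 in this assay is thus a step that the limit leaves unreadable from compound 3 to compound 4, most likely another limit. Compound 4 is estimated at 30000 nM, with a range from 12000 nM to 100000 nM.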

Compound 4, half-maximal inhibitory concentration: > 20000 nM
Compound 4: no number, only a limit; the forecaster's own chance of this, stated with the estimate: 85%; the middle value does not contradict the limit.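

Compound 4 also gives only a limit, so neither step into it, from compound 2 or from compound 3, can be read: the limit of > 20000 nM in this assay, at which 4 of the 4 values shown sit. The compounds shown leave open whether adding methoxy groups changes activity at all in this assay.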